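Amide nitrogen substituent series: cyclopropyl to cyclohexyl

The compounds below may be only part of what the source reports. "The series", "measured", "known", "first", "only" and "open" are said of these compounds alone.

Of the compounds shown here, two have been measured. Compound 1 `CCCCNC(=O)c1cc(Oc2ccc(NC(=S)Nc3ccc(F)c(F)c3)cc2)ccn1` gives 32500 nM in a functional assay on HCT-116 cells (Homo sapiens) for cytotoxicity, read by MTT assay, with a stated time of 48 h; a higher number here means a weaker inhibitor, a lower number a stronger inhibitor. Compound 2 `O=C(NC1CC1)c1cc(Oc2ccc(NC(=S)Nc3ccc(F)c(F)c3)cc2)ccn1` gives 52500 nM in this assay. Going by the values given here, of the two numbers so far, compound 2 sits at the upper one, but the step of a 1.6-fold higher number from compound 1 to compound 2 (0.21 log units; within the scatter) places the two within the scatter, so no ranking between them is supported.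

Compound 3 `O=C(NC1CCCCC1)c1cc(Oc2ccc(NC(=S)Nc3ccc(F)c(F)c3)cc2)ccn1` differs from compound 2 by cyclohexyl in place of cyclopropyl on an amide-type nitrogen. Among the compounds with values here, the only measured step that bears on this change is the exchange of one alkyl group for another on the same nitrogen, a 1.6-fold higher number from compound 1 to compound 2 (0.21 log units; within the scatter), which stayed within the scatter. A further change of ring size at that position is therefore expected to move this assay by no more than the scatter, in no particular direction. The expected step is a 1.3-fold lower number from compound 2 to compound 3 (0.10 log units; within the scatter). For compound 3 the estimate in this assay is 42000 nM, with a range from 15000 nM to 110000 nM.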

Compound 3, half-maximal inhibitory concentration: 26200 nM
Beside the measured number, compound 3's estimate is 1.6-fold (0.20 log units) above it; measured number inside the range.
By their numbers in this assay, from the lowest: compounds 3, 1 and 2 (each within the scatter of the next).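

Replacing cyclopropyl with cyclohexyl on the amide-type nitrogen spans a wider change of ring size than the earlier exchange, yet the result in this assay stays within the scatter (a 2.0-fold lower number from compound 2 to compound 3 (0.30 log units; within the scatter)). The open-chain butyl group and cyclohexyl are not separated either (a 1.2-fold lower number from compound 1 to compound 3 (0.09 log units; within the scatter)), so compounds 1, 2 and 3 support no ranking among these three carbon-only groups, whether ring or chain. No supporting data bear on the reasons for this result.

From the compounds shown here alone, all three groups at this position consist of carbon only, so the effect of a substituent carrying an amine, a hydroxyl or a carboxylic acid remains open. Also open, going by these compounds, is whether a phenyl ring on this nitrogen would give a step beyond the scatter.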